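Trading an Ester Side Group on Compound 3

The source may hold more compounds than are shown below. What is called first, only, known or untested is meant among the compounds shown, and "the series" means these compounds.

In a functional assay on HeLa cells (Homo sapiens) for cytotoxicity, read by MTT assay (on this read-out higher numbers stand for weaker inhibition and lower numbers for stronger inhibition), compound 1 `CC(=O)OCCC(=O)O[C@H](CC=C(C)C)C1=CC(=O)c2c(O)ccc(O)c2C1=O` gives 17300 nM, compound 2 `CCCCC(O)CC(=O)O[C@H](CC=C(C)C)C1=CC(=O)c2c(O)ccc(O)c2C1=O` gives 72200 nM and compound 3 `CC(C)=CC[C@@H](OC(=O)CC(O)c1ccccc1)C1=CC(=O)c2c(O)ccc(O)c2C1=O` gives 44500 nM. Compound 3 thus sits within the scatter of compound 2, with a 1.6-fold lower number from compound 2 to compound 3 (0.21 log units; within the scatter), and clear of compound 1, with a 2.6-fold higher number from compound 1 to compound 3 (0.41 log units; beyond the scatter). Compound 4 `CC(C)=CC[C@@H](OC(=O)C1CCCO1)C1=CC(=O)c2c(O)ccc(O)c2C1=O` keeps the shared core but carries oxolan-2-yl in place of 2-hydroxy-2-phenylethyl on a carbonyl carbon. For the measured compounds named here, no measured step makes this exact swap. The nearest guides are changes within the same side group, and they stayed modest, such as a 4.2-fold higher number from compound 1 to compound 2 (0.62 log units; beyond the scatter). A small shift, not beyond the scatter, is therefore expected: a 1.5-fold lower number from compound 3 to compound 4 (0.17 log units; within the scatter). Compound 4 is estimated at 30000 nM, with an expected range from 12000 nM to 72000 nM.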

Compound 4, half-maximal inhibitory concentration: 17000 nM
Compound 4: middle estimate off by 1.8-fold (0.25 log units), on the high side, within the range that was stated.
By their numbers in this assay, from the lowest: compounds 4 and 1 (each within the scatter of the next); then compounds 3 and 2 (each within the scatter of the next).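

At this place, on a carbonyl carbon, the ring oxolan-2-yl gives a 2.6-fold lower number from compound 3 to compound 4 (0.42 log units; beyond the scatter) and a 4.2-fold lower number from compound 2 to compound 4 (0.63 log units; beyond the scatter), so it outperforms both side groups that carry a hydroxy group. Against 2-acetoxyethyl, which has no free hydroxy group, it gives a 1.0-fold lower number from compound 1 to compound 4 (0.01 log units; within the scatter), so a ring is not needed to reach this level. Nothing available explains these differences.

On these data alone, it remains open whether the ring oxygen matters, which a plain cyclopentyl ring would test. An amine on the side group is also untested here.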